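Ether chain length: ethoxy to propoxy on the shared core

This account rests on a few compounds, and the source may have more. Where it says the series, first, only, none or still open, it means among the compounds named here.

Compound 1 `COc1cc(C(=O)N(C)C)nn1-c1ccccc1` and compound 2 `CCOc1cc(C(=O)N(C)C)nn1-c1ccccc1` share one core and differ only in the ether chain. Going by the values given here, in a functional assay on the whole organism (strain Wistar) for inhibition, with Rattus norvegicus as the target, read by paw edema, with stated times of 30 min and 3 h, at a dose of 100 mg/kg by the oral route (on this read-out higher numbers stand for more inhibition at the one dose given (going by the name of the read-out) and lower numbers for less inhibition), compound 1 gives 47.5%, while compound 2 gives 65.8%; the single step measured so far, a number 18.3 percentage points higher from compound 1 to compound 2 (beyond the scatter), places compound 2 at the top of the two numbers in hand, the nearest value being that of compound 1.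

Compound 3 `CCCOc1cc(C(=O)N(C)C)nn1-c1ccccc1` is not yet measured. Its difference from compound 2 is methyl in place of hydrogen on a saturated chain carbon, two bonds along the chain from an oxygen on an aromatic ring, the same kind of one-carbon lengthening seen in the earlier step, cut one bond further out. That earlier step is the only one bearing on the question, and it was modest. A second lengthening need not repeat the gain; a smaller rise, or a number within the scatter, is the more cautious expectation. Compound 3 is therefore expected to give 70%, with a range from 55% to 85%, in this assay. The expected step is a number 4.2 percentage points higher from compound 2 to compound 3 (within the scatter).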

Compound 3, a percentage reported as inhibition, in the whole organism at one dose (the size of the read-out at that dose, not a potency): 26.2%
Beside the measured number, compound 3's estimate is 43.8 percentage points above it, and the stated range ends above it.
By their numbers in this assay, from the lowest: compound 3; then compound 1; then compound 2.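

In this assay the ether chain does not respond in one direction: ethoxy to propoxy gives a number 39.6 percentage points lower from compound 2 to compound 3 (beyond the scatter) and so reverses the rise seen at the previous one-carbon lengthening. The propoxy chain also ends up under the shortest ether of the set, with a number 21.3 percentage points lower from compound 1 to compound 3 (beyond the scatter) as the step, which makes ethoxy the high point among these three chains and leaves compound 3 against any reading of longer chain, higher number. Nothing in hand bears on why the number drops at this chain length.

Open, going by these compounds, is whether a butoxy or still longer chain stays low or recovers, and whether a branched isopropoxy chain or a cyclopropylmethoxy group behaves like ethoxy or like propoxy. With a single dose, the numbers also leave open how these ethers would rank at other doses.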